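Triazole-linked terpenoid esters: aryl swap on the triazole nitrogen

The source may report more compounds than this note shows. Statements on the series, on what has been measured and on what is new or still open speak of the compounds shown alone.

Measured compounds:
Compound 1, `C/C(=C\CC/C(C)=C/CC[C@@H]1[C@@]2(C)CCC(=O)C(C)(C)[C@H]2CC[C@@]1(C)O)CC/C=C(\C)C(=O)OCc1cn(-c2cccc([N+](=O)[O-])c2)nn1`, in a functional assay on DU-145 cells (Homo sapiens) for antiproliferative activity, read by MTT assay, with a stated time of 48 h (a higher number here means a weaker inhibitor, a lower number a stronger inhibitor), gives > 150000 nM, which is a limit of this assay and not a number.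
Compound 2, `C/C(=C\CC/C(C)=C/CC[C@@H]1[C@@]2(C)CCC(=O)C(C)(C)[C@H]2CC[C@@]1(C)O)CC/C=C(\C)C(=O)OCc1cn(-c2cccc(Br)c2)nn1`, gives > 150000 nM, again a limit of this assay.
Compound 3, `C/C(=C\CC/C(C)=C/CC[C@@H]1[C@@]2(C)CCC(=O)C(C)(C)[C@H]2CC[C@@]1(C)O)CC/C=C(\C)C(=O)OCc1cn(C[C@@H]2O[C@H](n3ccc(=O)[nH]c3=O)[C@H]3OC(C)(C)O[C@H]32)nn1`, gives > 150000 nM, also a limit of this assay.

Compound 1 therefore stands at the assay limit, and nothing separates it from the other two measured compounds; all three sit there (the limit of > 150000 nM in this assay, at which 3 of the 3 values shown sit). Among the measured compounds shown here, the single step between compounds that differ in one place, a step that the two limits leave unreadable from compound 1 to compound 2, cannot be read, since both ends are limits.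

Compound 4, `C/C(=C\CC/C(C)=C/CC[C@@H]1[C@@]2(C)CCC(=O)C(C)(C)[C@H]2CC[C@@]1(C)O)CC/C=C(\C)C(=O)OCc1cn(-c2ccccc2Cl)nn1`, differs from compound 1 by 2-chlorophenyl in place of 3-nitrophenyl on an aromatic nitrogen. For the measured compounds named here, the only measured step on this part of the shared core is the unreadable one from compound 1 to compound 2, so no size or direction of change can be drawn from it. On the evidence of compound 1 at its limit, compound 4 is expected to remain at or near that limit as well, with an expected step of a number no higher from compound 1 to compound 4 (the limit leaves the size open). The estimate for compound 4 in this assay is 150000 nM, with a range from 80000 nM to 300000 nM.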

Compound 4, half-maximal inhibitory concentration: > 150000 nM
Compound 4: no number, only a limit (the forecaster's own chance of this, stated with the estimate: 85%); the middle value lies on the limit itself.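

Compound 4, like compound 1 and compound 2, gives only a limit in this assay, so the steps among these compounds cannot be read: the limit of > 150000 nM in this assay, at which 4 of the 4 values shown sit.

The compounds shown leave open whether any group on this aromatic nitrogen of the shared core gives a measurable value.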